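The compounds below may be only part of what the source reports. "The series", "measured", "known", "first", "only" and "open" are said of these compounds alone.

Measured in an assay on isolated protein for inhibition of Amine oxidase [flavin-containing] A (Homo sapiens), read by fluorescence, with a stated time of 30 min; a higher number here means a weaker inhibitor, a lower number a stronger inhibitor:
Compound 1 `CCN(CCCn1sc2cc(OC)c(OC)cc2c1=O)Cc1ccccc1N(C)C` gives 16600 nM.
Compound 2 `COc1cc2sn(CCCCN(C)Cc3ccccc3)c(=O)c2cc1OC` gives 8900 nM.
Compound 3 `CCN(CCCCn1sc2cc(OC)c(OC)cc2c1=O)Cc1ccccc1` gives 19900 nM.

Compound 3 shows the highest number of the three; compound 1 lies within the scatter of it, while compound 2 stands a clear step away. Within the data shown here, the only single-point step measured is a 2.2-fold higher number from compound 2 to compound 3 (0.35 log units; beyond the scatter), which alters the group on the amine nitrogen rather than the benzyl group, so it does not bear directly on the change at hand. Compound 4 `CCN(CCCCn1sc2cc(OC)c(OC)cc2c1=O)Cc1ccccc1OC` differs from compound 3 by methoxy in place of hydrogen on an aromatic carbon. Compound 1 also bears a substituted benzyl group, but with a shorter chain as well, and its value differs from that of compound 3 only within the scatter, so no strong lead is available. For compound 4 the expected step is a 1.2-fold lower number from compound 3 to compound 4 (0.09 log units; within the scatter), none beyond the scatter. Compound 4 is therefore estimated at 16000 nM, with a range from 6000 nM to 40000 nM.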

Compound 4, half-maximal inhibitory concentration: 9600 nM
Estimate against measurement, compound 4: 1.7-fold (0.22 log units) above; the measured number falls inside the stated range.
By their numbers in this assay, from the lowest: compounds 2, 4, 1 and 3 (each within the scatter of the next, the first and the last beyond it).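

Benzyl to 2-methoxybenzyl gives a 2.1-fold lower number from compound 3 to compound 4 (0.32 log units; beyond the scatter) in this assay, the first single-change reading on this aromatic ring. The aromatic carbon ortho to a large group therefore accepts methoxy, and the number falls modestly rather than rises. Nothing measured here explains the step.

Going by these compounds, whether a fluorine or a hydroxyl on the same carbon gives a similar step remains open, as does methoxy on other carbons of the ring. Also open, on these data alone, is whether 2-methoxybenzyl gives the same step on the methyl amine of compound 2.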